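From 4-fluorophenyl to 1-benzothiophen-2-yl on a sulfonamide nitrogen

A few compounds are considered here, and "the series" means these few. Any claim that something is new, unique, unknown or untested is made for them only; others in the source may bear on it.

Measured so far in a physicochemical assay for lipophilicity, at pH 7.4; on this read-out higher numbers stand for higher lipophilicity and lower numbers for lower lipophilicity
Compound 1 `CCS(=O)(=O)c1ccc(CN(CC(C)C)S(=O)(=O)c2ccc3c(c2)C(O)CC(C2CCOCC2)O3)nc1` gives 1.42
Compound 2 `CC(C)CN(c1ccc(F)cc1)S(=O)(=O)c1ccc2c(c1)C(O)CC(C1CCOCC1)O2` gives 3.39
Compound 3 `CCc1ccc(N(CC(C)C)S(=O)(=O)c2ccc3c(c2)C(O)CC(CC2CCOCC2)O3)cc1` gives 4.44

Compound 2 stands second highest of the three, under compound 3 and over compound 1. Compound 4 `CC(C)CN(c1cc2ccccc2s1)S(=O)(=O)c1ccc2c(c1)C(O)CC(C1CCOCC1)O2` differs from compound 2 by 1-benzothiophen-2-yl in place of 4-fluorophenyl on a sulfonamide nitrogen with 1-benzothiophen-2-yl in place of 4-fluorophenyl on a sulfonamide nitrogen. For the measured compounds named here, only one measured step touches that nitrogen, the large a number 1.97 log units higher from compound 1 to compound 2 (beyond the scatter) and it exchanged a different group, so it is a loose guide. Here both groups carry no net charge and the entering one has more heavy atoms. What is expected in this assay is a number 0.71 log units higher from compound 2 to compound 4 (beyond the scatter) upward and moderate in size. Compound 4 is expected at 4.1 and 3.6 to 4.6 is the estimated range.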

Compound 4, distribution coefficient: 3.92
Beside the measured number, compound 4's estimate is 0.18 log units above it; the measured number falls inside the stated range.
By their numbers in this assay, from the lowest: compound 1; then compound 2; then compound 4; then compound 3.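

In this assay the position now shows that exchanging one uncharged aromatic group for another can still shift the number, with 1-benzothiophen-2-yl in place of 4-fluorophenyl on the sulfonamide nitrogen giving a number 0.53 log units higher from compound 2 to compound 4 (beyond the scatter) as a modest step. The wider exchange gives a number 2.50 log units higher from compound 1 to compound 4 (beyond the scatter) and so remains far larger than that step. Nothing available explains the size of either step. On these data alone, how a phenyl group carrying an amine or a carboxylic acid would read at this nitrogen remains open.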